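Tolerance notes: from phenylsulfanyl to methoxy

The source may report more compounds than this note shows. Statements on the series, on what has been measured and on what is new or still open speak of the compounds shown alone.

Compound 1 `[N-]=[N+]=NCc1ncnc2c1ncn2[C@@H]1O[C@H](CO)[C@@H](O)[C@H]1O` and compound 2 `OC[C@H]1O[C@@H](n2cnc3c(CSc4ccccc4)ncnc32)[C@H](O)[C@@H]1O` both run into assay limits. In a functional assay on Huh-7 cells (Homo sapiens) for cytotoxicity, read by MTT assay, with a stated time of 3 days (a higher number here means that more compound is tolerated, a lower number that less compound is tolerated), compound 1 gives > 250000 nM, which is a limit and not a number. Compound 2 gives > 100000 nM in this assay, likewise a limit. The step that the two limits leave unreadable from compound 1 to compound 2 thus cannot be read, and compound 2 stands at one of the two limits seen (the limit of > 100000 nM in this assay, at which 1 of the 2 values shown sits). Compound 3 `COCc1ncnc2c1ncn2[C@@H]1O[C@H](CO)[C@@H](O)[C@H]1O` differs from compound 2 by methoxy in place of phenylsulfanyl on a saturated chain carbon bound to an aromatic carbon. Among the compounds with values here, no measured step bears on this change. Compound 3 is expected to show a step that the limit leaves unreadable from compound 2 to compound 3 of no size beyond the scatter. Compound 3 is estimated at 200000 nM (range 100000 nM to 300000 nM).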

Compound 3, half-maximal cytotoxic concentration: > 100000 nM
Compound 3 gave a limit, no number (the forecaster's own chance of this, stated with the estimate: 80%); the middle value lies beyond the limit too.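

Within the data shown here, compound 3 also gives a limit and not a number, and no step among compound 1, compound 2 and compound 3 can be read in this assay. On these data alone, whether azido, phenylsulfanyl and methoxy differ in tolerance remains open.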